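Amide to urea exchange on the shared core

This account rests on a few compounds, and the source may have more. Where it says the series, first, only, none or still open, it means among the compounds named here.

For the measured compounds named here, in a functional assay on cells (Pituitary gland cell) for antagonist activity at Gonadotropin-releasing hormone receptor (Rattus norvegicus) (a lower number here means a stronger inhibitor, a higher number a weaker inhibitor), compound 1 `Cc1cc(C)cc(-c2c(O)nc3cc(Cl)c(NC(=O)c4cnccn4)cc3c2OCCC2CCCCN2)c1` gives 1920 nM, the highest of the two numbers measured so far. Compound 2 `Cc1cc(C)cc(-c2c(O)nc3cc(Cl)c(NC(=O)Nc4cccnc4)cc3c2OCCC2CCCCN2)c1` gives 1300 nM, and the step of a 1.5-fold lower number from compound 1 to compound 2 (0.17 log units; within the scatter) stays within the scatter. Compound 3 `Cc1cc(C)cc(-c2c(O)nc3cc(Cl)c(NC(=O)Nc4ccccn4)cc3c2OCCC2CCCCN2)c1` carries (pyridin-2-yl)amino in place of pyrazin-2-yl on a carbonyl carbon. Going by the values given here, the only measured step that bears on this is the same kind of exchange at the same carbonyl carbon, which produced a 1.5-fold lower number from compound 1 to compound 2 (0.17 log units; within the scatter), so nothing beyond the scatter is expected here either. The estimate for compound 3 is 1300 nM, with a range from 500 nM to 3500 nM, which is expected to amount to a 1.5-fold lower number from compound 1 to compound 3 (0.17 log units; within the scatter).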

Compound 3, half-maximal inhibitory concentration: 463 nM
The estimate for compound 3 lay 2.8-fold (0.45 log units) above the measured number; measured number below the stated range.
By their numbers in this assay, from the lowest: compound 3; then compounds 2 and 1 (each within the scatter of the next).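

In this assay, this exchange at the carbonyl carbon now gives a change beyond the scatter (a 4.1-fold lower number from compound 1 to compound 3 (0.62 log units; beyond the scatter)), which the earlier pair did not show. The urea nitrogen alone does not set the number: pyridin-2-yl in place of pyridin-3-yl on the amide-type nitrogen also gives a step beyond the scatter (a 2.8-fold lower number from compound 2 to compound 3 (0.45 log units; beyond the scatter)). No supporting measurement bears on this difference.

Going by these compounds, whether pyridin-2-yl gives a similar number directly on the carbonyl carbon, without the urea nitrogen, stays open. So does the result of a plain phenyl ring on that nitrogen.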